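This account rests on a few compounds, and the source may have more. Where it says the series, first, only, none or still open, it means among the compounds named here.

Working notes on the series. In an ADME assay on microsomes from liver (Mus musculus) for metabolic stability, using NADPH, with a stated time of 10 min (a higher number here means that more of the compound is left, a lower number that less of the compound is left), compound 3 `NCCCCN(C[C@H]1Cc2nccnc2CN1)[C@H]1CCCc2cccnc21` gives 77%. Compound 1 `NCCCCN(C[C@@H]1Cc2ncccc2CN1)[C@H]1CCCc2cccnc21` gives 75% and compound 2 `NCCCCN(C[C@H]1Cc2cccnc2CN1)[C@H]1CCCc2cccnc21` gives 69%, so both sit within the usual scatter of compound 3, and compound 3 shares the top of this small set with compound 1.

The next compound is compound 4 `NCCCCN(C[C@@H]1Cc2nccnc2CN1)[C@H]1CCCc2cccnc21`. The change is the two compounds have the same atoms and bonds and differ only in configuration as drawn: 1 of 2 stereo elements differ; a stereocentre at a saturated ring carbon is drawn R in compound 3 and S in compound 4: a stereocentre at a saturated ring carbon is drawn R in compound 3 and S in compound 4.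

For the measured compounds named here, no two measured compounds differ in one place only, so the series gives no direct reading of such a change. Going by the values given here, the only guide is the narrow spread in this assay: compound 1 at 75% and compound 2 at 69% both stay within the scatter of compound 3 despite their differences in the core. The expected step of a number 2 percentage points lower from compound 3 to compound 4 (within the scatter) therefore lies within the scatter, with no direction expected. For compound 4 the estimated value is 75%, with an expected range of 63% to 87%.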

Compound 4, percent of the compound remaining: 73%
Compound 4: middle estimate off by 2 percentage points, on the high side, within the range that was stated.
By their numbers in this assay, from the lowest: compounds 2, 4, 1 and 3 (each within the scatter of the next).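

This pair gives the series its first direct reading of a single change, and that change is confined to one stereocentre at a saturated ring carbon: the fact that compounds 3 and 4 differ only in the configuration as drawn. In this assay, turning this centre from R to S as drawn gives a number 4 percentage points lower from compound 3 to compound 4 (within the scatter). For this pair, therefore, the configuration at this position leaves the percent of compound remaining within the usual scatter, and the reading gives no direction for the change.

From the compounds shown here alone, it remains open whether the other stereo element would give a similar reading when changed on its own, and whether the same change at this centre would read alike on the core of compound 2. Going by these compounds, it is also open whether this reading would hold with a longer chain or with a carboxylic acid in place of the amine.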